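A few compounds are considered here, and "the series" means these few. Any claim that something is new, unique, unknown or untested is made for them only; others in the source may bear on it.

Compound 1 `CC(=O)Oc1ccc(/C=C/C(=O)OCCCSc2nc(-c3ccc(S(N)(=O)=O)cc3)n(-c3ccc(F)cc3)n2)cc1OC(C)=O`: in a functional assay on B16-F10 cells (Mus musculus) for antiproliferative activity, read by MTT assay, with a stated time of 72 h (on this read-out higher numbers stand for weaker inhibition and lower numbers for stronger inhibition), compound 1 gives 10900 nM.
Compound 2 `CS(=O)(=O)c1ccc(-c2nc(SCCOC(=O)/C=C/c3ccc(O)c(O)c3)nn2-c2ccccc2)cc1`: in this assay compound 2 gives 15000 nM.

Compound 2 stands at the highest of the two numbers; its nearest neighbour is compound 1, and the gap between them lies within the usual scatter, so the two values show no order. Compound 3 `NS(=O)(=O)c1ccc(-c2nc(SCCOC(=O)/C=C/c3ccc(O)c(O)c3)nn2-c2ccccc2)cc1` has not yet been measured in this assay. It differs from compound 2 in one place: amino in place of methyl on a sulfonyl sulfur. Going by the values given here, no measured pair in this set isolates that change. Among the compounds with values here, compound 1 carries the sulfamoyl group that enters, but it differs from compound 2 in other places as well, so its value shows only that a sulfamoyl compound and a methylsulfonyl compound sit within the scatter of each other. A step in this assay is therefore expected to be small, none beyond the scatter, in either direction. The step is expected to be a 1.2-fold lower number from compound 2 to compound 3 (0.06 log units; within the scatter). Compound 3 is estimated to give 13000 nM, with a range from 5000 nM to 32000 nM.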

Compound 3, half-maximal inhibitory concentration: 15000 nM
Compound 3: middle estimate off by 1.2-fold (0.06 log units), on the low side; the range from low to high includes it.
By their numbers in this assay, from the lowest: compounds 1, 2 and 3 (each within the scatter of the next).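

Compound 2 and compound 3 differ only in amino in place of methyl on a sulfonyl sulfur, so this pair isolates the change that compound 1 could not. In this assay, going from methylsulfonyl to sulfamoyl gives no change at the digits printed from compound 2 to compound 3 (within the scatter), which shows that, on this scaffold, the exchange and the hydrogen-bond donor it adds leave the antiproliferative read-out where it was. Nothing measured here explains this result.

The compounds shown leave open whether a dimethylamino or ethyl group on the same sulfonyl sulfur, or a carboxylic acid in place of the whole methylsulfonyl group, would also leave the number in place. They also leave open whether the same exchange reads alike on the other parts of compound 1.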